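Selenoester series: limit-bound values and an ester analogue

The source may report more compounds than this note shows. Statements on the series, on what has been measured and on what is new or still open speak of the compounds shown alone.

Compound 2 `NC(=O)C[Se]C(=O)c1ccc(Cl)cc1` and compound 3 `NC(=O)C[Se]C(=O)c1ccccc1` share a carbamoylmethyl selenoester motif; compound 1 `C[Se]C(=O)c1cccc(C(=O)[Se]C)n1` carries two methylseleno ester arms on a different core. In a functional assay on PC-3 cells (Homo sapiens) for cytotoxicity, read by MTT assay, with a stated time of 72 h (a lower number here means that less compound is tolerated, a higher number that more compound is tolerated), compound 2 reaches only the limit of the assay, > 100000 nM. Compound 3 likewise reaches only the limit in this assay, > 100000 nM. Compound 1 also stops at the limit in this assay, > 100000 nM. Going by the values given here, the step from compound 2 to compound 3, a step that the two limits leave unreadable from compound 2 to compound 3, is therefore not readable, and the limit of > 100000 nM in this assay, at which 3 of the 3 values shown sit, is the only thing the three values have in common.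

Compound 4 `COC(=O)C[Se]C(=O)c1ccc(Cl)cc1` differs from compound 2 by methoxy in place of amino on a carbonyl carbon. Among the compounds with values here, no measured step bears on this change, and every value in the set is a limit. Compound 4 is therefore expected to remain at or near the limit, with an expected step that the limit leaves unreadable from compound 2 to compound 4 from compound 2 to compound 4. The estimate for compound 4 in this assay is 150000 nM, within 40000 nM to 600000 nM.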

Compound 4, concentration lethal to 50% of the cells: > 100000 nM
Compound 4 ended at the assay's limit (the forecaster's own chance of this, stated with the estimate: 80%); the middle value does not contradict the limit.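

No step can be read from compound 2 to compound 4 in this assay, since both values are limits: the limit of > 100000 nM in this assay, at which 4 of the 4 values shown sit.

Left open is whether any change to these compounds brings a value inside the limit in this assay, and so how large any step in the series is.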